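Replacing the Pyrazole with a Pyridazin-4-yl Group

This account rests on a few compounds, and the source may have more. Where it says the series, first, only, none or still open, it means among the compounds named here.

In an assay on cells for inhibition of cytochrome P450 11B2, mitochondrial (Homo sapiens), read by HPLC, with a stated time of 90 min (a lower number here means a stronger inhibitor, a higher number a weaker inhibitor), compound 2 `Fc1ccc2nc(-c3cn[nH]c3)n(C3CC3)c2c1` gives 782 nM, the highest of the two numbers reported, with compound 3 `Fc1ccc2nc(-c3cccnn3)n(C3CC3)c2c1` nearest at 412 nM. For compound 1 `Fc1ccc2nc(-c3cnco3)n(C3CC3)c2c1` the result is only a limit of this assay, > 10000 nM. The step from compound 2 to compound 4 `Fc1ccc2nc(-c3ccnnc3)n(C3CC3)c2c1` is pyridazin-4-yl in place of 1H-pyrazol-4-yl on an aromatic carbon. The measured steps that bear on it are a 1.9-fold lower number from compound 2 to compound 3 (0.28 log units; within the scatter), together with the larger steps of an at least 12-fold lower number from compound 1 to compound 2 (1.10 log units; beyond the scatter) and an at least 24-fold lower number from compound 1 to compound 3 (1.38 log units; beyond the scatter). Going by the values given here, with a 1.9-fold lower number from compound 2 to compound 3 (0.28 log units; within the scatter) as the nearest precedent, a pyridazin-3-yl group in place of the same 1H-pyrazol-4-yl group, compound 4 is expected to show a 1.7-fold lower number from compound 2 to compound 4 (0.24 log units; within the scatter). The estimate for compound 4 is 450 nM, within a range from 150 nM to 1400 nM.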

Compound 4, half-maximal inhibitory concentration: 330 nM
Beside the measured number, compound 4's estimate is 1.4-fold (0.13 log units) above it; measured number inside the range.
By their numbers in this assay, from the lowest: compounds 4, 3 and 2 (each within the scatter of the next, the first and the last beyond it). At a limit, above all of these: compound 1.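

In this assay, compound 4 shows that a six-membered aromatic ring with 0 hydrogen-bond donors can replace the 1H-pyrazol-4-yl group at this place with a 2.4-fold lower number from compound 2 to compound 4 (0.37 log units; beyond the scatter), a step beyond the scatter that compound 3 did not reach. Pyridazin-4-yl in place of pyridazin-3-yl gives a 1.2-fold lower number from compound 3 to compound 4 (0.10 log units; within the scatter), so the two pyridazinyl groups cannot be told apart here. The step from the 1,3-oxazol-5-yl group, an at least 30-fold lower number from compound 1 to compound 4 (1.48 log units; beyond the scatter), is only a bound, as compound 1 stands at a limit: the limit of > 10000 nM in this assay, at which 1 of the 4 values shown sits.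

The compounds shown leave open whether a pyridine or pyrimidine ring would serve at this place as well as pyridazin-4-yl. They also leave open what an amine or a methyl group on that ring would do to the number.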